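Aryl swaps at one aromatic carbon of the shared core

The compounds below may be only part of what the source reports. "The series", "measured", "known", "first", "only" and "open" are said of these compounds alone.

The series keeps one core and varies the aromatic group attached to it. Compound 1 `c1cncc(-c2ccccc2OCC2=NCCN2)c1` gives 109% in a functional assay with Alpha-1A adrenergic receptor (Homo sapiens) as the target, read by calcium flux; on this read-out lower numbers stand for smaller maximal responses and higher numbers for larger maximal responses. Compound 2 `Cc1cccc(-c2ccccc2OCC2=NCCN2)n1` gives 80% in this assay. Compound 3 `c1c[nH]c(-c2ccccc2OCC2=NCCN2)c1` gives 99% in this assay, the second highest of the three numbers; the step of a number 10 percentage points lower from compound 1 to compound 3 (within the scatter) lies within the scatter, while compound 2 stands beyond the scatter below compound 3.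

Compound 4 `c1ccc(-c2ncc[nH]2)c(OCC2=NCCN2)c1` has not been measured. Its change from compound 3 is 1H-imidazol-2-yl in place of 1H-pyrrol-2-yl on an aromatic carbon; the entering ring brings a hydrogen-bond acceptor that the leaving ring lacks, at the same aromatic carbon ortho to a group of 7 heavy atoms. Going by the values given here, the only measured step at this position is a number 10 percentage points lower from compound 1 to compound 3 (within the scatter), a swap of one aromatic ring for another that stayed within the scatter; compound 2 shows that a change at this carbon can also pull the maximum response down beyond the scatter. Among the compounds with values here, no measured step moves from a five-membered ring with one hetero atom to one with two hetero atoms. The expected step is therefore small, a number 4 percentage points lower from compound 3 to compound 4 (within the scatter), with no direction beyond the scatter. Compound 4 is estimated at 95%, between 75% and 115%.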

Compound 4, largest response reached (reported as maximum), in percent of the reference or control that the assay uses: 122%
Compound 4: the middle estimate sits 27 percentage points below what was measured; the whole stated range lies below it.
By their numbers in this assay, from the lowest: compound 2; then compounds 3 and 1 (each within the scatter of the next); then compound 4.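

In this assay, 1H-imidazol-2-yl in place of 1H-pyrrol-2-yl gives a number 23 percentage points higher from compound 3 to compound 4 (beyond the scatter) and is the first listed step at this aromatic carbon to rise beyond the scatter. Against the six-membered ring, 1H-imidazol-2-yl in place of pyridin-3-yl gives a number 13 percentage points higher from compound 1 to compound 4 (beyond the scatter) even though compound 1 and compound 3 lie within the scatter of each other, so this position separates two five-membered aromatic rings that both carry a hydrogen-bond donor, and the swap that does so adds a second hetero atom and a hydrogen-bond acceptor. These counts describe the change, but nothing available bears on the origin of the rise.

The series does not yet separate the role of the added ring nitrogen from that of the 1H-imidazol-2-yl ring as a whole; an oxazol-2-yl or thiazol-2-yl ring, or a 1-methylimidazol-2-yl ring that lacks the ring hydrogen, would test this. Going by these compounds, it is also open whether a methyl group on the 1H-imidazol-2-yl ring would keep the response seen with compound 4 in this assay or lower it.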